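This account rests on a few compounds, and the source may have more. Where it says the series, first, only, none or still open, it means among the compounds named here.

Series notes. Going by the values given here, compound 2 `CC1=C(C(=O)Nc2ccc(F)c(Cl)c2)C(c2ccccc2Cl)NC(=S)N1` in a functional assay on COLO 205 cells (Homo sapiens) for cytotoxicity, read by sulforhodamine B assay, with a stated time of 48 h (on this read-out lower numbers stand for stronger inhibition of growth and higher numbers for weaker inhibition of growth), gives 24000 nM, the highest number of the three measured so far. Compound 3 `CC1=C(C(=O)Nc2ccc(Cl)c(Cl)c2)C(c2cccc(Cl)c2)NC(=O)N1` gives 7940 nM and compound 1 `CC1=C(C(=O)Nc2ccc(F)c(Cl)c2)C(c2cccc(Oc3ccccc3)c2)NC(=O)N1` gives 6310 nM; both stand beyond the scatter below compound 2, yet each differs from compound 2 in more than one place, so no single-change step can be read off the measured set. The next compound, compound 4 `COc1cccc(C2NC(=S)NC(C)=C2C(=O)Nc2ccc(F)c(Cl)c2)c1`, keeps the core of compound 2 and alters one group: 3-methoxyphenyl in place of 2-chlorophenyl on a saturated ring carbon. Among the compounds with values here, no measured pair isolates this change, and the two lower values of compound 1 and compound 3 cannot be attributed to the aryl group alone. Compound 2 at 24000 nM is therefore the only anchor. The expected step is a 1.6-fold lower number from compound 2 to compound 4 (0.20 log units; within the scatter), a small move toward a lower number that is not expected to exceed the scatter. The estimate for compound 4 in this assay is 15000 nM, with a range from 5000 nM to 45000 nM.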

Compound 4, concentration for 50% growth inhibition: 26900 nM
For compound 4 the middle estimate is 1.8-fold (0.25 log units) below the measured one, and the stated range covers the measured number.
By their numbers in this assay, from the lowest: compounds 1 and 3 (each within the scatter of the next); then compounds 2 and 4 (each within the scatter of the next).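

In this assay, going by these compounds alone, the first single-change step is a 1.1-fold higher number from compound 2 to compound 4 (0.05 log units; within the scatter) for 3-methoxyphenyl in place of 2-chlorophenyl on the saturated ring carbon. Within the data shown here, with the rest of compound 2 kept, these two aryl groups stand level at this position in this read-out, which the earlier compounds could not show, since each differs from compound 2 in more than one place. Nothing on hand offers an explanation for this result.

On these data alone, whether the level result extends to other groups on this aryl ring, such as an amine, a carboxylic acid or a longer chain in place of the methoxy, stays open. Also open, as far as these compounds go, is whether the same change reads alike on the core of compound 1.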